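This account rests on a few compounds, and the source may have more. Where it says the series, first, only, none or still open, it means among the compounds named here.

Among the measured compounds shown here, in an ADME assay on microsomes from liver (Mus musculus) for metabolic stability, with a stated time of 10 min (on this read-out higher numbers stand for a more stable compound and lower numbers for a less stable compound), compound 2 (`CS(=O)(=O)N1CCC(C(=O)N2CC[C@](c3ccc(C(F)(C(F)(F)F)C(F)(F)F)cc3)(S(=O)(=O)c3ccc(F)cc3)C2)CC1`) gives 69% as the only number so far. Compound 1 (`CC(=O)N1CCC(C(=O)N2CC[C@](c3ccc(C(F)(C(F)(F)F)C(F)(F)F)cc3)(S(=O)(=O)c3ccc(F)cc3)C2)CC1`) stands at "not determined" (no result reported) and offers no comparison. Compound 3 (`O=C(O)C1CCN(C(=O)N2CC[C@](c3ccc(C(F)(C(F)(F)F)C(F)(F)F)cc3)(S(=O)(=O)c3ccc(F)cc3)C2)CC1`) differs from compound 2 by 4-carboxypiperidin-1-yl in place of 1-(methylsulfonyl)piperidin-4-yl on a carbonyl carbon with the shared core unchanged. For the measured compounds named here, no measured step sizes this swap, so the expectation rests on the single value of compound 2 and on the structural change alone. A small upward move in this assay is expected, possibly no larger than the usual scatter. The estimated step is a number 9 percentage points higher from compound 2 to compound 3 (within the scatter) with considerable uncertainty. Compound 3 is expected at 78% with a range from 58% to 95% for this measurement.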

Compound 3, percent of the compound remaining: 88%
The estimate for compound 3 lay 10 percentage points below the measured number; low and high end bracket the measured number.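

In this assay, among the compounds shown here, 4-carboxypiperidin-1-yl in place of 1-(methylsulfonyl)piperidin-4-yl on a carbonyl carbon gives a number 19 percentage points higher from compound 2 to compound 3 (beyond the scatter) as the first sized step at this position. This place in the series therefore responds to the group it carries. Nothing on hand gives a reason for the step.

The swap alters the end group and the ring atom bound to the carbonyl carbon together, and the compounds shown do not separate the two. Also open, as far as these compounds go, is how a methyl ester or an amine in place of the carboxylic acid would read in this assay.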